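The compounds below may be only part of what the source reports. "The series", "measured", "known", "first", "only" and "open" are said of these compounds alone.

Of the compounds shown here, two have been measured in a functional assay on CHO-K1 cells for antagonist activity at C-X-C chemokine receptor type 3 (Homo sapiens), read by FLIPR and calcium flux; a lower number here means a stronger inhibitor, a higher number a weaker inhibitor. Compound 1 `C[C@H]1CN(S(=O)(=O)C[C@]23CC[C@H](CC2=O)C3(C)C)CCN1c1ccc(C(F)(F)F)cn1` carries a methyl group on its piperazine ring and a pyridine bearing a trifluoromethyl group; in this assay compound 1 gives 158 nM. Compound 2 `CC1(C)[C@@H]2CC[C@@]1(CS(=O)(=O)N1CCN(c3ncc(C(F)(F)F)cn3)CC1)C(=O)C2` has an unsubstituted piperazine and a pyrimidine bearing a trifluoromethyl group; in this assay compound 2 gives 316 nM. On these two numbers compound 2 stands at the higher end, but the gap between compound 2 and compound 1 lies within the usual scatter, so the two values cannot be told apart with confidence.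

Compound 3 `C[C@H]1CN(S(=O)(=O)C[C@]23CC[C@H](CC2=O)C3(C)C)CCN1c1ncc(C(F)(F)F)cn1` keeps the pyrimidine of compound 2 and adds the ring methyl that compound 1 already has. The change from compound 2 to compound 3 is methyl in place of hydrogen on a saturated ring carbon. Going by the values given here, no measured pair isolates this single change, so there is no directly comparable step to lean on. Since compound 1 in this assay gives 158 nM with such a methyl in place, the expected step from compound 2 to compound 3 is small, a 1.6-fold lower number from compound 2 to compound 3 (0.20 log units; within the scatter), not beyond the scatter. Compound 3 is estimated at 200 nM, within a range of 80 nM to 500 nM.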

Compound 3, half-maximal inhibitory concentration: 126 nM
For compound 3 the middle estimate is 1.6-fold (0.20 log units) above the measured one, and the stated range covers the measured number.
By their numbers in this assay, from the lowest: compounds 3, 1 and 2 (each within the scatter of the next, the first and the last beyond it).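

Methyl in place of hydrogen on a saturated ring carbon, next to the ring atom that bears a 5-(trifluoromethyl)pyrimidin-2-yl group, gives a 2.5-fold lower number from compound 2 to compound 3 (0.40 log units; beyond the scatter) in this assay, a modest step but the first single-place change here that stands clear of the scatter. With that methyl present, 5-(trifluoromethyl)pyrimidin-2-yl in place of 5-(trifluoromethyl)pyridin-2-yl gives a 1.3-fold lower number from compound 1 to compound 3 (0.10 log units; within the scatter), so this assay does not separate these two groups on the methylated compounds. Nothing available here accounts for the effect of the methyl on the measured number.

The compounds shown leave open whether the methyl gives a similar step when the 5-(trifluoromethyl)pyridin-2-yl group is present, since the effect has been read on only one pair. They also leave open what happens with the opposite spatial arrangement of the methyl, or with an ethyl or hydroxymethyl group on the same ring carbon.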